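A few compounds are considered here, and "the series" means these few. Any claim that something is new, unique, unknown or untested is made for them only; others in the source may bear on it.

Measured so far:
compound 1 `O=C1CSC(c2cccc(F)c2)N1CCN1CCCCC1`, in an ADME assay on Vero cells (Chlorocebus sabaeus) for cytotoxicity, read by neutral red uptake, tested at 394 ug/mL (on this read-out higher numbers stand for a weaker effect at the one concentration tested and lower numbers for a stronger effect), compound 1 gives 60%
compound 2 `O=C1CSC(c2ccc(Cl)cc2)N1CCN1CCCCC1`, compound 2 gives 28%
compound 3 `O=C1CSC(c2ccccc2Cl)N1CCN1CCCCC1`, compound 3 gives 31%

Compound 3 stands second highest of the three numbers; compound 2 lies nearest, a number 3 percentage points higher from compound 2 to compound 3 (within the scatter), and compound 1 lies furthest, a number 29 percentage points lower from compound 1 to compound 3 (beyond the scatter). Compound 4 `O=C1CSC(c2ccccc2[N+](=O)[O-])N1CCN1CCCCC1` differs from compound 3 by nitro in place of chloro on an aromatic carbon. Among the measured compounds shown here, none of the measured steps exchanges a halogen for a nitro group: a number 32 percentage points lower from compound 1 to compound 2 (beyond the scatter) and a number 29 percentage points lower from compound 1 to compound 3 (beyond the scatter) concern only a change of halogen and its position on the same ring, and a number 3 percentage points higher from compound 2 to compound 3 (within the scatter). For the measured compounds named here, no step therefore bears directly on this change, and the expectation is no step beyond the scatter, a number 1 percentage points higher from compound 3 to compound 4 (within the scatter). Compound 4 is estimated at 32% in this assay, expected between 14% and 56%.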

Compound 4, a percentage reported as activity, at one concentration (the size of the read-out at that concentration, not a potency): 100%
Beside the measured number, compound 4's estimate is 68 percentage points below it, outside the stated range (above it).
By their numbers in this assay, from the lowest: compounds 2 and 3 (each within the scatter of the next); then compound 1; then compound 4.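

In this assay, among the compounds shown here, nitro in place of chloro on an aromatic carbon, ortho to a large group, gives a number 69 percentage points higher from compound 3 to compound 4 (beyond the scatter), so compound 4 shows a weaker effect at the one concentration tested than compound 3. The earlier steps shown here only varied a halogen and its position, whereas this one shows that a non-halogen group at this place can shift the read-out strongly upward. No measurement shown accounts for this shift.

On these data alone, whether an amine, a nitrile or a carboxylic acid at this place would behave like nitro stays open. So does whether nitro would have the same effect at the ring positions held by the halogens of compound 1 and compound 2.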